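Replacing hydroxy with carbamoyl on the cyclohexyl ring

The source may report more compounds than this note shows. Statements on the series, on what has been measured and on what is new or still open speak of the compounds shown alone.

Measured compounds:
compound 1, `N#Cc1cnc(NCc2cnccc2C(F)(F)F)cc1N[C@H]1CC[C@@H](O)CC1`: 4500 nM
compound 2, `N#Cc1cnc(NCc2cnccc2C(F)(F)F)cc1NC[C@H]1CC[C@@H](O)CC1`: 500 nM
compound 3, `N#Cc1cnc(NCc2cnccc2C(F)(F)F)cc1NC[C@H]1CC[C@H](O)CC1`: 2000 nM

In an assay on isolated protein for inhibition of protein kinase C delta type (Homo sapiens), read by TR-FRET, with a stated time of 2 h (on this read-out lower numbers stand for stronger inhibition and higher numbers for weaker inhibition), compound 1 gives 4500 nM, the highest of the three numbers and so the weakest inhibitor here. The measured steps move away from it: a 9.0-fold lower number from compound 1 to compound 2 (0.95 log units; beyond the scatter) and a 2.3-fold lower number from compound 1 to compound 3 (0.35 log units; beyond the scatter), both introducing a (4-hydroxycyclohexyl)methyl in place of 4-hydroxycyclohexyl on a nitrogen on an aromatic ring. Between those two, a 4.0-fold higher number from compound 2 to compound 3 (0.60 log units; beyond the scatter), a difference that rests only on (the fact that compounds 2 and 3 differ only in the configuration as drawn).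

Compound 4, `N#Cc1cnc(NCc2cnccc2C(F)(F)F)cc1N[C@H]1CC[C@@H](C(N)=O)CC1`, keeps the 4-hydroxycyclohexyl-type attachment of compound 1 but changes the group at the far end of that ring: carbamoyl in place of hydroxy on a saturated ring carbon. Among the measured compounds shown here, none of the measured steps alters the hydroxy itself; they concern the linker and the configuration. For the measured compounds named here, there is therefore no measured step that bears directly on this change, and no basis for expecting a shift beyond the scatter in either direction. Compound 4 is expected to give about 4000 nM, within 1000 nM to 15000 nM, meaning an expected step of a 1.1-fold lower number from compound 1 to compound 4 (0.05 log units; within the scatter).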

Compound 4, half-maximal inhibitory concentration: 400 nM
Compound 4: the middle estimate sits 10-fold (1.00 log units) above what was measured, outside the stated range (below it).
By their numbers in this assay, from the lowest: compounds 4 and 2 (each within the scatter of the next); then compound 3; then compound 1.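

The far end of the ring matters in its own right. Among the compounds shown here, with the attachment of compound 1 kept, carbamoyl in place of hydroxy gives an 11-fold lower number from compound 1 to compound 4 (1.05 log units; beyond the scatter), the first step here that touches the end group itself. For the compounds shown here, the methyl linker is therefore not the only change that moves away from compound 1: against the two linked alcohols the steps read a 1.3-fold lower number from compound 2 to compound 4 (0.10 log units; within the scatter) and a 5.0-fold lower number from compound 3 to compound 4 (0.70 log units; beyond the scatter), although each of these two steps changes both the linker and the end group.

Still open, as far as these compounds go, is whether carbamoyl on the methyl-linked ring would add to the gain, whether its mirror-type configuration would behave alike, and whether a carboxylic acid or an amine at the same place would do the same. Nothing shown here accounts for the gain from carbamoyl.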